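The compounds below may be only part of what the source reports. "The series", "measured", "known", "first", "only" and "open" are said of these compounds alone.

Measured so far in a physicochemical assay for lipophilicity, read by HPLC, at pH 7.4; on this read-out lower numbers stand for lower lipophilicity and higher numbers for higher lipophilicity:
- Compound 1 `O=C(O)COc1ccc([C@H]2CC[C@]3(CC2)OOC2(O3)C3CC4CC(C3)CC2C4)cc1Cl` gives 3.2
- Compound 2 `O=C(O)COc1ccc([C@H]2CC[C@]3(CC2)OOC2(O3)C3CC4CC(C3)CC2C4)cc1C(=O)O` gives 1.9

Compound 1 holds the higher of these two numbers. Going by the values given here, the single measured step is a number 1.30 log units lower from compound 1 to compound 2 (beyond the scatter).

Compound 3 `O=C(O)COc1c(Cl)cc([C@H]2CC[C@]3(CC2)OOC2(O3)C3CC4CC(C3)CC2C4)cc1Cl` differs from compound 1 in one place: chloro in place of hydrogen on an aromatic carbon. This is chloro in place of hydrogen on an aromatic carbon, ortho to a carboxymethoxy group and meta to a chloro group.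

The measured step is only a loose guide. It exchanges the chloro group for carboxy, while compound 3 keeps that chloro and gains a second one. Among the compounds with values here, no measured step shows chloro replacing hydrogen. Within the data shown here, compound 1, at 3.2, lies on the higher side of the only measured step, so a modest rise in this assay is expected, well short of that large step. The estimated step is a number 0.40 log units higher from compound 1 to compound 3 (beyond the scatter). Compound 3 is expected at 3.6, with an estimated range from 3.2 to 4.1.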

Compound 3, distribution coefficient: 3.3
Compound 3: middle estimate off by 0.30 log units, on the high side; the range from low to high includes it.
By their numbers in this assay, from the lowest: compound 2; then compounds 1 and 3 (each within the scatter of the next).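

In this assay, placing chloro on this aromatic carbon, ortho to a carboxymethoxy group and meta to a chloro group, gives a number 0.10 log units higher from compound 1 to compound 3 (within the scatter), so the added chloro leaves no change that can be told from repeat-measurement noise. The earlier step, a number 1.30 log units lower from compound 1 to compound 2 (beyond the scatter), replaced the existing chloro with carboxy, and it said nothing about this second ring position, where hydrogen and chloro can now be compared directly. No supporting measurement here explains why this read-out stays level.

The compounds shown leave open how this same position would read with a different group, such as an amine or a nitrile. Going by these compounds, it also remains open whether a methoxy group here would shift the read-out beyond the scatter.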